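Second chloro on the core: compound 2 to compound 3

This account rests on a few compounds, and the source may have more. Where it says the series, first, only, none or still open, it means among the compounds named here.

Two close benzylic chlorides sit on the shared core. Compound 1 `ClCc1cccc(Cn2cnc3c(Cl)ncnc32)c1` gives 2230 nM in a functional assay on SK-MEL-28 cells (Homo sapiens) for cytotoxicity, read by sulforhodamine B assay, with a stated time of 48 h; a lower number here means a stronger inhibitor of growth, a higher number a weaker inhibitor of growth. Compound 2 `ClCc1ccccc1Cn1cnc2ncnc(Cl)c21` gives 4460 nM in this assay, the higher of the two numbers, and its nearest neighbour, compound 1, lies within the scatter of it, so no order between them can be claimed.

Compound 3 `ClCc1ccccc1Cn1cnc2nc(Cl)nc(Cl)c21` is not yet measured. It differs from compound 2 by chloro in place of hydrogen on an aromatic carbon, a chloro in place of hydrogen on an aromatic carbon, between two ring nitrogen atoms, meta to the chloro group already present. For the measured compounds named here, no measured pair shows such a change, so there is no step to lean on. The expectation is a step from compound 2 to compound 3 of a 1.3-fold lower number from compound 2 to compound 3 (0.11 log units; within the scatter), not beyond the scatter in either direction. Compound 3 is thus estimated at 3500 nM, with a range from 1200 nM to 10000 nM.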

Compound 3, concentration for 50% growth inhibition: 350 nM
For compound 3 the middle estimate is 10-fold (1.00 log units) above the measured one; measured number below the stated range.
By their numbers in this assay, from the lowest: compound 3; then compounds 1 and 2 (each within the scatter of the next).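

For the compounds shown here, the chloro in place of hydrogen on an aromatic carbon, between two ring nitrogen atoms, brings a 13-fold lower number from compound 2 to compound 3 (1.11 log units; beyond the scatter) in this assay, the first step to lie beyond the scatter. The earlier compounds shown here carry hydrogen at this carbon and so said nothing about it; this single change now shows that growth inhibition responds strongly to substitution at this position of the shared core. Going by these compounds alone, nothing measured so far accounts for the size of this step.

Still open, as far as these compounds go, is whether the step belongs to chloro itself or whether an amine or a methoxy group on the same carbon would give a comparable step. Also open, from the compounds shown here alone, is whether the same chloro on the core of compound 1 would lower its number as far.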